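The source may report more compounds than this note shows. Statements on the series, on what has been measured and on what is new or still open speak of the compounds shown alone.

Three analogues sharing one core have been measured in a functional assay on PC-3 cells (Homo sapiens) for cytotoxicity, read by sulforhodamine B assay, with a stated time of 48 h; a higher number here means a weaker inhibitor, a lower number a stronger inhibitor. Compound 1 `O=CCN1N=C(c2ccc3ccccc3c2)CC1c1ccccc1` gives 7400 nM. Compound 2 `O=CCN1N=C(c2ccc3ccccc3c2)CC1c1cccc(Cl)c1Cl` gives 17900 nM, and compound 3 `O=CCN1N=C(c2ccc3ccccc3c2)CC1c1cccc(Br)c1` gives 10900 nM. Among these three numbers compound 3 stands second highest: against compound 1 it differs by a 1.5-fold higher number from compound 1 to compound 3 (0.17 log units; within the scatter), and against compound 2 by a 1.6-fold lower number from compound 2 to compound 3 (0.22 log units; within the scatter), both within the scatter, so the three compounds cannot be placed in any order of potency on what is known. Within the data shown here, the only step beyond the scatter is a 2.4-fold higher number from compound 1 to compound 2 (0.38 log units; beyond the scatter), which is still modest.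

Compound 4 `COc1ccc(C2CC(c3ccc4ccccc4c3)=NN2CC=O)cc1` carries 4-methoxyphenyl in place of 3-bromophenyl on a saturated ring carbon. Among the measured compounds shown here, no measured step involves a methoxy group, so the expectation rests on the three substituent changes at this saturated ring carbon, all of which stayed within a narrow band. The step of a 1.2-fold lower number from compound 3 to compound 4 (0.08 log units; within the scatter) is therefore expected to lie within the scatter, with no clear direction. Compound 4 is estimated at 9000 nM, expected between 4000 nM and 20000 nM.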

Compound 4, half-maximal inhibitory concentration: 4530 nM
Estimate against measurement, compound 4: 2.0-fold (0.30 log units) above; the measured number falls inside the stated range.
By their numbers in this assay, from the lowest: compounds 4, 1, 3 and 2 (each within the scatter of the next, the first and the last beyond it).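

In this assay, among these compounds, the 4-methoxyphenyl group on the saturated ring carbon gives the first steps beyond the scatter towards a lower number: a 2.4-fold lower number from compound 3 to compound 4 (0.38 log units; beyond the scatter) and a 4.0-fold lower number from compound 2 to compound 4 (0.60 log units; beyond the scatter). The position therefore does respond to the choice of aryl group, over a wider span than the halogenated compounds and the unsubstituted phenyl had shown, although the span remains modest. Methoxy in place of hydrogen does not separate from the parent, however, at a 1.6-fold lower number from compound 1 to compound 4 (0.21 log units; within the scatter), so compound 1 cannot be ranked against either compound 3 or compound 4, and no data shown here explain the differences.

Compound 3 and compound 4 differ in both the substituent and its place on the phenyl ring, so the compounds shown do not tell which of these matters. As far as these compounds go, how a hydroxy group or an amine would compare with the methoxy group also remains open.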